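The source may hold more compounds than are shown below. What is called first, only, known or untested is meant among the compounds shown, and "the series" means these compounds.

For the measured compounds named here, compound 1 `O=c1[nH]/c(=N\OCCOc2ccccc2)ccn1[C@@H]1O[C@H](COP(=O)(O)OP(=O)(O)OP(=O)(O)O)[C@@H](O)[C@H]1O` gives 430 nM in a functional assay on 1321-N1 cells for agonist activity at P2Y purinoceptor 4 (Homo sapiens), read by scintillation counting and inositol phosphate accumulation (on this read-out higher numbers stand for an effect only at larger amounts of compound and lower numbers for an effect already at smaller amounts), the highest of the two numbers measured so far, though only by a margin within the scatter. Compound 2 `O=c1[nH]/c(=N\OCCCc2cccnc2)ccn1[C@@H]1O[C@H](COP(=O)(O)OP(=O)(O)OP(=O)(O)O)[C@@H](O)[C@H]1O` gives 300 nM in this assay, and the step of a 1.4-fold lower number from compound 1 to compound 2 (0.16 log units; within the scatter) carries (pyridin-3-yl)methyl in place of phenoxy at the same position. Compound 3 `O=c1[nH]/c(=N\OCCCc2ccsc2)ccn1[C@@H]1O[C@H](COP(=O)(O)OP(=O)(O)OP(=O)(O)O)[C@@H](O)[C@H]1O` shows the change ((thiophen-3-yl)methyl in place of phenoxy on a saturated chain carbon, two bonds along the chain from an oxygen). Going by the values given here, the one measured step that bears on this exchange, a 1.4-fold lower number from compound 1 to compound 2 (0.16 log units; within the scatter), stayed within the scatter, so in this assay no step beyond the scatter is expected, a 1.2-fold lower number from compound 1 to compound 3 (0.09 log units; within the scatter). Compound 3 is therefore estimated at 350 nM, with a range from 150 nM to 900 nM.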

Compound 3, half-maximal effective concentration: 20 nM
Beside the measured number, compound 3's estimate is 18-fold (1.24 log units) above it, and the stated range ends above it.
By their numbers in this assay, from the lowest: compound 3; then compounds 2 and 1 (each within the scatter of the next).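

In this assay this position proves sensitive to the terminal ring: a 22-fold lower number from compound 1 to compound 3 (1.33 log units; beyond the scatter) and a 15-fold lower number from compound 2 to compound 3 (1.18 log units; beyond the scatter) both lie beyond the scatter, whereas the earlier exchange, a 1.4-fold lower number from compound 1 to compound 2 (0.16 log units; within the scatter), stayed within it. With the propyl chain held constant, thiophen-3-yl in place of pyridin-3-yl is enough for a large step, and compound 3 stands apart from both other compounds. Nothing measured here accounts for these steps.

Open, from the compounds shown here alone, is whether thiophen-2-yl, furan-3-yl or plain phenyl on the same propyl chain would follow compound 3. Also open, going by these compounds, is how a butyl chain carrying thiophen-3-yl would compare.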